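Chain extension on the amide side of the shared core

The source may report more compounds than this note shows. Statements on the series, on what has been measured and on what is new or still open speak of the compounds shown alone.

Measured in a functional assay on the whole organism for inhibition, with Mus musculus as the target; on this read-out lower numbers stand for an effect already at smaller amounts and higher numbers for an effect only at larger amounts of compound:
compound 1 `CCNCC(=O)Nc1cccc2c1CN(C)CC2c1ccc(Cl)cc1`: 6.4 mg/kg
compound 2 `CCCCNCC(=O)Nc1cccc2c1CN(C)CC2c1ccc(Cl)cc1`: 3.9 mg/kg
compound 3 `CCNCC(=O)Nc1cccc2c1CN(C)CC2c1ccc(C)cc1`: 5.6 mg/kg

Compound 1 and compound 2 differ by ethyl in place of hydrogen on a saturated chain carbon, two bonds along the chain from an amine nitrogen; this step gives a 1.6-fold lower number from compound 1 to compound 2 (0.22 log units; within the scatter). Compound 1 and compound 3 differ in the core by methyl in place of chloro on an aromatic carbon; this step gives a 1.1-fold lower number from compound 1 to compound 3 (0.06 log units; within the scatter). All three numbers lie within the scatter of one another.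

Compound 4 `CCCCNCC(=O)Nc1cccc2c1CN(C)CC2c1ccc(C)cc1` is not yet measured. It differs from compound 3 by ethyl in place of hydrogen on a saturated chain carbon, two bonds along the chain from an amine nitrogen, the same change as from compound 1 to compound 2, at the same place on the chain. For compound 4 the step of a 1.6-fold lower number from compound 3 to compound 4 (0.19 log units; within the scatter) is expected to match the earlier one, resting on a 1.6-fold lower number from compound 1 to compound 2 (0.22 log units; within the scatter) seen in the chloro series. Compound 4 is therefore estimated at 3.6 mg/kg, with a range from 2 mg/kg to 6.5 mg/kg.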

Compound 4, dose for half-maximal effect: about 2.5 mg/kg
Compound 4: the middle estimate sits 1.4-fold (0.16 log units) above what was measured, within the range that was stated.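

In this assay the change from ethylamino to butylamino on the methyl-bearing core gives a 2.2-fold lower number from compound 3 to compound 4 (0.35 log units; beyond the scatter), and it carries over from the chloro-bearing core without a detectable difference: the same change on two cores in this assay, a 1.6-fold lower number (0.22 log units; within the scatter) from compound 1 to compound 2 and a 2.2-fold lower number (0.35 log units; beyond the scatter) from compound 3 to compound 4, 1.4-fold (0.14 log units) apart, within the scatter of two such steps. Methyl in place of chloro, now read with butylamino on the chain, gives a 1.6-fold lower number from compound 2 to compound 4 (0.19 log units; within the scatter), and it too agrees with the earlier step: the same change on two cores in this assay, a 1.1-fold lower number (0.06 log units; within the scatter) from compound 1 to compound 3 and a 1.6-fold lower number (0.19 log units; within the scatter) from compound 2 to compound 4, 1.4-fold (0.14 log units) apart, within the scatter of two such steps. Among these compounds, this shows agreement across a single pair of cores only; it does not show that the chain step has the same size on other cores, and only the step on the methyl-bearing core lies beyond the scatter.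

From the compounds shown here alone, it remains open whether a longer chain than butyl or a cyclic amine would extend the chain step. Going by these compounds, whether methoxy or trifluoromethyl in place of chloro would behave as methyl does is also open.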